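The source may hold more compounds than are shown below. What is called first, only, known or untested is meant among the compounds shown, and "the series" means these compounds.

Measured so far: compound 1 `O=c1ccn([C@@H]2O[C@H](COP(=O)(O)OP(=O)(O)OP(=O)(O)O)[C@@H](O)[C@H]2O)c(=S)[nH]1` with 50 nM and compound 2 `Cn1c(=O)ccn([C@@H]2O[C@H](COP(=O)(O)OP(=O)(O)OP(=O)(O)O)[C@@H](O)[C@H]2O)c1=O` with 564 nM, both in an in vitro functional assay on 1321-N1 cells for agonist activity at P2Y purinoceptor 2 (Homo sapiens); on this read-out higher numbers stand for an effect only at larger amounts of compound and lower numbers for an effect already at smaller amounts.

Among the measured compounds shown here, compound 2 gives the highest number of the two; the only other compound, compound 1, sits an 11-fold higher number from compound 1 to compound 2 (1.05 log units; beyond the scatter) away from it, a gap beyond the scatter. Compound 3 `O=c1[nH]c(=O)n([C@@H]2O[C@H](COP(=O)(O)OP(=O)(O)OP(=O)(O)O)[C@@H](O)[C@H]2O)cc1Br` differs from compound 2 by a group of 9 heavy atoms (4 carbon, 2 nitrogen, 2 oxygen, 1 bromine; one six-membered aromatic ring with 2 hetero atoms) in place of a group of 9 heavy atoms (5 carbon, 2 nitrogen, 2 oxygen; one six-membered aromatic ring with 2 hetero atoms), on a saturated ring carbon. For the measured compounds named here, the single measured step, from compound 1 to compound 2, changes the same group on the same ring carbon but swaps in a different pair of rings, so it bears on the move to compound 3 only in showing that changes at this position can shift the read-out by a large margin. On that basis compound 3 is expected to land at 300 nM in this assay, with a range from 80 nM to 1200 nM. The step from compound 2 to compound 3 is thus estimated as a 1.9-fold lower number from compound 2 to compound 3 (0.27 log units; within the scatter), a modest fall in the number.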

Compound 3, half-maximal effective concentration: 347 nM
Compound 3: the middle estimate sits 1.2-fold (0.06 log units) below what was measured; the measured number falls inside the stated range.
By their numbers in this assay, from the lowest: compound 1; then compounds 3 and 2 (each within the scatter of the next).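

Exchanging the group on this saturated ring carbon for the bromine-bearing one gives a 1.6-fold lower number from compound 2 to compound 3 (0.21 log units; within the scatter), so in this assay compound 2 and compound 3 cannot be told apart, even though their groups differ in their atoms and in their hydrogen-bond donors and acceptors. The sulfur-bearing group of compound 1 stays apart, with a 6.9-fold higher number from compound 1 to compound 3 (0.84 log units; beyond the scatter), so compound 1 keeps the lowest number of the three, and not every change at this position brings a large shift. Nothing available here speaks to what lies behind these numbers.

As far as these compounds go, whether the gap rests on the sulfur alone stays open: compound 1 differs from compound 2 and from compound 3 in more than that one atom. Also open, from the compounds shown here alone, is how a group carrying chlorine or an amine in place of the bromine would read in this assay.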